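Working notes: from compound 3 to compound 4

The source may report more compounds than this note shows. Statements on the series, on what has been measured and on what is new or still open speak of the compounds shown alone.

Measured in a functional assay on KB cells (Homo sapiens) for inhibition, read by sulforhodamine B assay, with a stated time of 72 h; on this read-out lower numbers stand for stronger inhibition of growth and higher numbers for weaker inhibition of growth:
- compound 1 `CNC(=O)/C=C/c1ccncc1-c1ccc2ccccc2c1`: > 10000 nM, a limit
- compound 2 `NNC(=O)CCc1ccncc1-c1ccc2ccccc2c1`: > 10000 nM, a limit
- compound 3 `COC1CN(C(=O)/C=C/c2ccncc2-c2ccc3ccccc3c2)C1`: > 10000 nM, a limit

Compound 3 has no number, only the limit > 10000 nM. The whole set reads the same way: the limit of > 10000 nM in this assay, at which 3 of the 3 values shown sit.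

Compound 4 `COC(=O)/C=C/c1ccncc1-c1ccc2ccccc2c1` has not been measured. The change is methoxy in place of 3-methoxyazetidin-1-yl on a carbonyl carbon.

The nearest measured change, on the same carbonyl carbon, is a step that the two limits leave unreadable from compound 1 to compound 3. The other change, at a different place, is a step that the two limits leave unreadable from compound 1 to compound 2. Neither gives a size that could be carried over. In this assay no step beyond the scatter is therefore expected, and no direction can be argued from these data. The expected step is a step that the limit leaves unreadable from compound 3 to compound 4. A reported limit is also the likely outcome for compound 4. The estimate for compound 4 is 15000 nM, with an expected range of 4000 nM to 50000 nM.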

Compound 4, concentration for 50% growth inhibition: 6730 nM
Compound 4: the middle estimate sits 2.2-fold (0.35 log units) above what was measured; the range from low to high includes it.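

Methoxy on the carbonyl carbon gives the first reading in this assay that is a number and not a limit. Against the other groups on that carbon, the record reads an at least 1.4-fold lower number from compound 3 to compound 4 (0.17 log units; that floor lies within the scatter) and an at least 1.4-fold lower number from compound 1 to compound 4 (0.17 log units; that floor lies within the scatter), while the change at the aromatic carbon reads an at least 1.4-fold lower number from compound 2 to compound 4 (0.17 log units; that floor lies within the scatter). All three steps are floors, so none establishes a size beyond the scatter, and the true gap stays hidden behind the shared limit: the limit of > 10000 nM in this assay, at which 3 of the 4 values shown sit.

Still open, as far as these compounds go, is how far compound 1, compound 2 and compound 3 lie from compound 4, since each of the three is recorded only as a limit. Also open, from the compounds shown here alone, is whether ethoxy or a carboxylic acid on the same carbonyl carbon would give a number in this assay.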